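A Hydroxyl Added to Two Different Cores

This account rests on a few compounds, and the source may have more. Where it says the series, first, only, none or still open, it means among the compounds named here.

Compound 1 `C=C1CC[C@@H]2[C@](C)(CCC[C@]2(C)C(=O)OC)[C@H]1CCc1ccc2c(OC(C)=O)ccc(OC(C)=O)c2c1` and compound 2 `C=C1CC[C@@H]2[C@](C)(CCC[C@]2(C)C(=O)OC)[C@H]1CCc1ccc2c(OC)ccc(OC)c2c1` differ in more than one place, and the difference between the two cores is not broken down here. In a functional assay on HT-29 cells (Homo sapiens) for cytotoxicity, read by sulforhodamine B assay, with a stated time of 72 h (a lower number here means a stronger inhibitor of growth, a higher number a weaker inhibitor of growth), compound 1 gives 500 nM. For compound 2 the this assay result is only a limit, > 6700 nM. Compound 3 `C=C1[C@H](O)C[C@@H]2[C@](C)(CCC[C@]2(C)C(=O)OC)[C@H]1CCc1ccc2c(OC(C)=O)ccc(OC(C)=O)c2c1` arises from compound 1 by hydroxy in place of hydrogen on a saturated ring carbon, and in this assay compound 3 gives 1000 nM, a step of a 2.0-fold higher number from compound 1 to compound 3 (0.30 log units; within the scatter). Compound 4 `C=C1CC[C@@H]2[C@](C)(CCC[C@]2(C)C(=O)OC)[C@]1(O)CCc1ccc2c(OC)ccc(OC)c2c1` arises from compound 2 by the same kind of change, (hydroxy in place of hydrogen on a saturated ring carbon), though the hydroxy now sits next to the ring atom that bears a fused ring and next to the ring atom that bears a methyl group, whereas in compound 3 it is two ring bonds from the ring atom that bears a fused ring and three ring bonds from the ring atom that bears a methyl group. Compound 4 is expected to give 10000 nM in this assay, an estimated step that the limit leaves unreadable from compound 2 to compound 4, because compound 2 already rests at the limit of > 6700 nM in this assay, at which 1 of the 3 values shown sits, and the earlier step stayed within the scatter.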

Compound 4, concentration for 50% growth inhibition: > 21500 nM
Compound 4: a limit, no number; the forecaster's own chance of this, stated with the estimate: 75%; middle value at least 2.1-fold (0.33 log units) away from the limit.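

In this assay, among these compounds, compound 4 gives only a limit of > 21500 nM and compound 2 also rests at a limit, so no step between these two compounds can be read. The compounds shown leave open whether adding the hydroxy changes growth inhibition on the core of compound 2 at all.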